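Allyl on the ring amine of compound 2

This account rests on a few compounds, and the source may have more. Where it says the series, first, only, none or still open, it means among the compounds named here.

Measured so far:
compound 1 `C=CCN1CCC(N2CCN(c3ccccc3)CC2)C(O)C1` — > 100 nM
compound 2 `OC1CCNCC1N1CCN(c2ccccc2)CC1` — > 100 nM

In an assay on PC-12 cells for displacement of a labelled ligand from vesicular acetylcholine transporter (Homo sapiens) (on this read-out lower numbers stand for stronger inhibition and higher numbers for weaker inhibition), compound 1 gives only a limit of the assay, > 100 nM. Compound 2 likewise gives only a limit in this assay, > 100 nM. Compound 2 thus stands at the limit of > 100 nM in this assay, at which 2 of the 2 values shown sit; no number is known for it, and none for the other compound either, so the two values show nothing more than that neither compound reached the measurable range. Among the compounds with values here, compound 1 and compound 2 differ in more than one place, and no single step connects them.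

Compound 3 `C=CCN1CCC(O)C(N2CCN(c3ccccc3)CC2)C1` differs from compound 2 by allyl in place of hydrogen on an amine nitrogen in a ring. No measured step sizes this change. Compound 1 also carries an allyl group on its ring amine and still gives only a limit in this assay, > 100 nM. The step from compound 2 to compound 3 is expected to remain within the scatter, at roughly a step that the limit leaves unreadable from compound 2 to compound 3. For compound 3 in this assay a value of 300 nM is estimated, in the range 80 nM to 3000 nM, with a further limit as the more likely outcome.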

Compound 3, half-maximal inhibitory concentration: > 100 nM
Compound 3 ended at the assay's limit; the forecaster's own chance of this, stated with the estimate: 75%; the middle value is on the limit's open side.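

No step can be read from compound 2 to compound 3, as both give only a limit, and all the compounds shown stand together at it: the limit of > 100 nM in this assay, at which 3 of the 3 values shown sit.

The compounds shown leave open what number any of them would reach in this assay, and whether allyl in place of hydrogen on the amine nitrogen in the ring shifts it.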